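The source may hold more compounds than are shown below. What is called first, only, known or untested is meant among the compounds shown, and "the series" means these compounds.

Of the compounds shown here, two with the same core have numbers so far in a functional assay on HCT-116 cells (Homo sapiens) for cytotoxicity, read by MTT assay, with a stated time of 72 h; on this read-out lower numbers stand for stronger inhibition and higher numbers for weaker inhibition. Compound 1 (`O=C1c2c[n+]([O-])c3ccccc3c2C(=O)c2c1c1ccccc1n2Cc1cn(CC(O)CO)nn1`) gives 250 nM, while compound 2 (`CN1CCN(CCCCn2c3c(c4ccccc42)C(=O)c2c[n+]([O-])c4ccccc4c2C3=O)CC1`) gives 10 nM, the lower of the two numbers. Compound 3 (`CCCCN1CCN(CCCCn2c3c(c4ccccc42)C(=O)c2c[n+]([O-])c4ccccc4c2C3=O)CC1`) keeps everything in compound 2 except for one change: propyl in place of hydrogen on a saturated chain carbon bound to an amine nitrogen in a ring. This is propyl in place of hydrogen on a saturated chain carbon bound to an amine nitrogen in a ring, which turns 4-methylpiperazin-1-yl into 4-butylpiperazin-1-yl. Among the measured compounds shown here, only one measured step bears on this question, and only loosely: a 25-fold lower number from compound 1 to compound 2 (1.40 log units; beyond the scatter). That large step replaced a whole side chain, so it shows that the side chain can matter, but it offers no direct measure of a change from methyl to butyl. The change in compound 3 is much smaller, so a much smaller step is expected, with only a slight lean towards a higher number. The expected step is a 1.5-fold higher number from compound 2 to compound 3 (0.18 log units; within the scatter). Compound 3 is estimated at 15 nM, with an expected range from 4 nM to 50 nM.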

Compound 3, half-maximal inhibitory concentration: 1920 nM
For compound 3 the middle estimate is 130-fold (2.11 log units) below the measured one, outside the stated range (above it).
By their numbers in this assay, from the lowest: compound 2; then compound 1; then compound 3.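

In this assay, the far end of the side chain proves highly sensitive: methyl to butyl, which turns 4-methylpiperazin-1-yl into 4-butylpiperazin-1-yl, gives a 190-fold higher number from compound 2 to compound 3 (2.28 log units; beyond the scatter). The earlier step from compound 1 to compound 2 replaced a whole side chain, so it could not show whether the group on the piperazine itself matters. This pair differs in that group alone, and the added propyl brings no ring, no hydrogen-bond donor or acceptor and no net charge, yet inhibition is much weaker, although no measurement shown explains this loss.

Going by these compounds, with only methyl and butyl to compare here, it remains open whether the number rises steadily as the chain grows or jumps sharply at one length, which 4-ethylpiperazin-1-yl and 4-propylpiperazin-1-yl groups could settle. On these data alone, it is also open whether a plain piperazine carrying only hydrogen, or a 2-hydroxyethyl chain of similar reach to butyl, would stay close to compound 2 or fall away like compound 3.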